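The source may report more compounds than this note shows. Statements on the series, on what has been measured and on what is new or still open speak of the compounds shown alone.

Working notes on the series, as read in an ADME assay on Huh-7 cells (Homo sapiens) for cytotoxicity, read by MTT assay, with a stated time of 4 h, at 37 degrees C; on this read-out higher numbers stand for lower toxicity in this test and lower numbers for higher toxicity in this test. Going by the values given here, compound 1 (`CCCCCNc1nc(N)nc2c1cc(-c1ccc(F)cc1)c(=O)n2C`) gives 79800 nM, the highest of the three numbers measured so far. Compound 3 (`Cn1c(=O)c(-c2c(F)cccc2F)cc2c(N)nc(Nc3ccccc3)nc21`) gives 10400 nM, and compound 2 (`O=C1Nc2nc(Nc3ccccc3)nc(On3nnc4ccccc43)c2CC1c1ccc(Cl)cc1Cl`) gives 5500 nM. Both lie lower than compound 1 by margins beyond the scatter. Among the compounds with values here, these three compounds do not differ from one another in a single place, so no measured step bears directly on the change now in question.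

Compound 4 (`CCCOCCNc1nc(N)nc2c1cc(-c1ccc(F)cc1)c(=O)n2C`) is still unmeasured. It keeps the core of compound 1 and alters only the chain: propoxy in place of propyl on a saturated chain carbon, two bonds along the chain from a nitrogen on an aromatic ring. In words, this is propoxy in place of propyl on a saturated chain carbon, two bonds along the chain from a nitrogen on an aromatic ring. Cut one bond further out, the same difference reads pentylamino to (2-propoxyethyl)amino.

Within the data shown here, with no measured precedent for this swap, the expectation stays anchored on compound 1 at 79800 nM. A slight upward move, not beyond the scatter, is expected: the estimated step is a 1.2-fold higher number from compound 1 to compound 4 (0.08 log units; within the scatter). For compound 4 the estimated value is 95000 nM, with an expected range of 45000 nM to 200000 nM.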

Compound 4, half-maximal cytotoxic concentration: 54300 nM
Beside the measured number, compound 4's estimate is 1.7-fold (0.24 log units) above it; measured number inside the range.
By their numbers in this assay, from the lowest: compounds 2 and 3 (each within the scatter of the next); then compounds 4 and 1 (each within the scatter of the next).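

At this place, on a saturated chain carbon, two bonds along the chain from a nitrogen on an aromatic ring, the series now has its first measured step: propoxy in place of propyl gives a 1.5-fold lower number from compound 1 to compound 4 (0.17 log units; within the scatter) in this assay and so shows no change that can be told apart from repeat measurement. The swap adds one oxygen and one hydrogen-bond acceptor to the chain, and on the core of compound 1 this addition leaves no readable mark on the number. No accompanying measurement speaks to the reason for this result.

Still open, on these data alone, is whether a longer chain, an amine or a carboxylic acid in place of the propoxy would also stay within the scatter in this assay or would move the number beyond it. A single step on a single core also leaves open whether propoxy in place of propyl would read the same way on any other core in the series.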